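From Compound 2 to Compound 3: an Expected Small Step

This account rests on a few compounds, and the source may have more. Where it says the series, first, only, none or still open, it means among the compounds named here.

Compound 2 `NS(=O)(=O)c1cc(-c2nnc(/C=C/c3cccc(Cl)c3)o2)c(Cl)cc1SCc1ccccc1` stands at the lower of the two numbers measured in a functional assay on MCF7 cells (Homo sapiens) for cytotoxicity, read by MTT assay, with a stated time of 72 h (a lower number here means a stronger inhibitor, a higher number a weaker inhibitor), where compound 2 gives 11000 nM. Compound 1 `CCOC(=O)c1cn(Cc2nnc(-c3cc(S(N)(=O)=O)c(SCc4ccccc4)cc3Cl)o2)nn1` gives 150000 nM in this assay, and the step of a 14-fold lower number from compound 1 to compound 2 (1.13 log units; beyond the scatter) is the only one measured so far. Compound 3 `NS(=O)(=O)c1cc(-c2nnc(/C=C/c3ccc(Br)cc3)o2)c(Cl)cc1SCc1ccccc1` has not yet been measured. The change from compound 2 to compound 3 is 4-bromophenyl in place of 3-chlorophenyl on a double-bonded chain carbon bound to a double-bonded chain carbon. Among the measured compounds shown here, the one measured step exchanged a whole group on the shared core and does not bear on this exchange of one phenyl for another; no measured step speaks to it, so the expectation rests on the change being small in kind. The expectation for compound 3 in this assay is therefore a step of no change at the digits printed from compound 2 to compound 3 (within the scatter) that stays within the scatter. Compound 3 is estimated at 11000 nM in this assay, with a range from 4000 nM to 30000 nM.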

Compound 3, half-maximal inhibitory concentration: 13000 nM
Estimate against measurement, compound 3: 1.2-fold (0.07 log units) below; low and high end bracket the measured number.
By their numbers in this assay, from the lowest: compounds 2 and 3 (each within the scatter of the next); then compound 1.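

In this assay the exchange of 3-chlorophenyl for 4-bromophenyl on a double-bonded chain carbon bound to a double-bonded chain carbon gives a 1.2-fold higher number from compound 2 to compound 3 (0.07 log units; within the scatter), so this place accepts a different halogen at a different ring position with no change that stands out from the scatter. The large step from the triazole-bearing group also holds for the new group, with a 12-fold lower number from compound 1 to compound 3 (1.06 log units; beyond the scatter), so it is not confined to 2-(3-chlorophenyl)ethenyl. Nothing measured accounts for the close match between the two halogenated phenyl groups.

The halogen and its ring position changed together, so the compounds shown cannot separate the two. On these data alone, whether a plain phenyl, or a phenyl carrying an amine or a carboxylic acid, would stay at this level remains open.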